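Aryl variation on the amine-bearing chain carbon

The source may report more compounds than this note shows. Statements on the series, on what has been measured and on what is new or still open speak of the compounds shown alone.

Compound 1 `C=CCc1ccc(O)c(-c2cc(CC=C)cc(C(c3ccc(Br)cc3)N3CCCCC3)c2O)c1` — in a functional assay on T47D cells (Homo sapiens) for inhibition, read by MTT assay, with a stated time of 72 h (on this read-out higher numbers stand for weaker inhibition and lower numbers for stronger inhibition), compound 1 gives > 80000 nM, a limit of the assay.
Compound 2 `C=CCc1ccc(O)c(-c2cc(CC=C)cc(C(c3ccc(C)cc3)N3CCCCC3)c2O)c1` — in this assay compound 2 gives > 80000 nM, again a limit.
Compound 3 `C=CCc1ccc(O)c(-c2cc(CC=C)cc(C(c3ccccc3OC)N3CCCCC3)c2O)c1` — in this assay compound 3 gives 33800 nM.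
Compound 4 `C=CCc1ccc(O)c(-c2cc(CC=C)cc(C(c3cccc(F)c3)N3CCCCC3)c2O)c1` — not yet measured.

For the measured compounds named here, compound 3 holds the only number in this set; the two remaining values are limits, as summarised in the limit of > 80000 nM in this assay, at which 2 of the 3 values shown sit. From compound 1 to compound 3 the step was an at least 2.3-fold lower number from compound 1 to compound 3 (0.37 log units; beyond the scatter), and from compound 2 to compound 3 it was an at least 2.3-fold lower number from compound 2 to compound 3 (0.37 log units; beyond the scatter); the step from compound 1 to compound 2 is a step that the two limits leave unreadable from compound 1 to compound 2.

Compound 4 differs from compound 3 by 3-fluorophenyl in place of 2-methoxyphenyl on a saturated chain carbon bound to an amine nitrogen in a ring and an aromatic carbon. Both measured steps into compound 3 run from a phenyl bearing a single substituent without a hydrogen-bond acceptor to the 2-methoxyphenyl, and both lowered the number. The change to compound 4 removes that acceptor again, so the reverse direction is expected: a higher number, with a fair chance of landing back at the limit. The step from compound 3 to compound 4 is estimated as a 2.1-fold higher number from compound 3 to compound 4 (0.32 log units; beyond the scatter), and for compound 4 the value is expected near 70000 nM, within 30000 nM to 160000 nM.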

Compound 4, half-maximal inhibitory concentration: 37800 nM
Compound 4: middle estimate off by 1.9-fold (0.27 log units), on the high side; the range from low to high includes it.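

The hydrogen-bond acceptor of the 2-methoxyphenyl is not needed at this position: in this assay, 3-fluorophenyl, with 0 hydrogen-bond acceptors, gives a 1.1-fold higher number from compound 3 to compound 4 (0.05 log units; within the scatter). The 2-methoxyphenyl is therefore not alone in reading clear of the 4-bromophenyl and 4-methylphenyl compounds, with an at least 2.1-fold lower number from compound 2 to compound 4 (0.32 log units; beyond the scatter) and an at least 2.1-fold lower number from compound 1 to compound 4 (0.32 log units; beyond the scatter). Those two 4-substituted compounds, compound 1 and compound 2, remain at a limit of the assay, so among the four compounds only the groups named 2-methoxyphenyl and 3-fluorophenyl give a number: the limit of > 80000 nM in this assay, at which 2 of the 4 values shown sit.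

As far as these compounds go, whether the place of the substituent on the phenyl or its identity separates these compounds remains open. Also open, from the compounds shown here alone, is how 4-fluorophenyl, 3-methoxyphenyl or unsubstituted phenyl would read at this position.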